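A few compounds are considered here, and "the series" means these few. Any claim that something is new, unique, unknown or untested is made for them only; others in the source may bear on it.

Measured so far in a functional assay on HCT-15 cells (Homo sapiens) for cytotoxicity, read by ELISA, with a stated time of 4 days; a higher number here means a weaker inhibitor, a lower number a stronger inhibitor:
- compound 1 `Clc1ccc(-c2cc(-c3ccoc3)cc(-c3ccco3)n2)s1`: 1280 nM
- compound 2 `Cc1ccc(-c2cc(-c3ccoc3)cc(-c3ccc(Cl)s3)n2)o1`: 790 nM
- compound 3 `Cc1cccc(-c2cc(-c3ccoc3)cc(-c3ccc(Cl)s3)n2)c1`: 880 nM

Compound 3, at 880 nM, lies within the scatter of the other two values, so the three compounds cannot be ranked. Compound 4 `Cc1ccc(-c2cc(-c3ccoc3)cc(-c3ccc(Cl)s3)n2)cc1` has 4-methylphenyl in place of 3-methylphenyl on an aromatic carbon.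

Two measured steps change the group at this carbon: a 1.5-fold lower number from compound 1 to compound 3 (0.16 log units; within the scatter) and a 1.1-fold higher number from compound 2 to compound 3 (0.05 log units; within the scatter). A third adds a methyl to the furan ring at this carbon: a 1.6-fold lower number from compound 1 to compound 2 (0.21 log units; within the scatter). All three are small and within the scatter. Going by the values given here, no measured pair compares the two methylphenyl groups directly, so the evidence is indirect and rests on only three compounds.

Even so, larger replacements at this carbon have left this assay within the scatter, so no change beyond the scatter is expected. The expected step is no change at the digits printed from compound 3 to compound 4 (within the scatter). For compound 4 the estimated value is 880 nM, with an expected range of 420 nM to 1800 nM.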

Compound 4, half-maximal inhibitory concentration: 1170 nM
Compound 4: the middle estimate sits 1.3-fold (0.12 log units) below what was measured, and the stated range covers the measured number.
By their numbers in this assay, from the lowest: compounds 2, 3, 4 and 1 (each within the scatter of the next).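

Moving the methyl gives the first direct comparison of the two methylphenyl groups at this carbon, the one next to the ring nitrogen, and in this assay it shows a 1.3-fold higher number from compound 3 to compound 4 (0.12 log units; within the scatter) and does not separate them. The 4-methylphenyl group is not separated from the furans either, with a 1.5-fold higher number from compound 2 to compound 4 (0.17 log units; within the scatter) against 5-methylfuran-2-yl and a 1.1-fold lower number from compound 1 to compound 4 (0.04 log units; within the scatter) against furan-2-yl, so all four groups at this carbon remain unranked. Nothing measured on hand offers an explanation for this flat picture.

The compounds shown hold only furan and methylphenyl rings at this carbon, so it stays open whether an amine, a carboxylic acid or a longer chain there would also stay within the scatter. From the compounds shown here alone, the furan-3-yl and 5-chlorothiophen-2-yl groups are the same throughout, so their bearing on the value is also open.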